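Benzyl in place of thiophen-2-yl on a sulfonyl sulfur

This account rests on a few compounds, and the source may have more. Where it says the series, first, only, none or still open, it means among the compounds named here.

Compound 1 `CCCCS(=O)(=O)N[C@@H](CNC(=O)c1ccc2c(c1)C(=O)N(CCC1CCNCC1)C2)C(=O)O`: 14 nM; 9 nM (2 entries)
Compound 2 `CCCCNC(=O)N[C@@H](CNC(=O)c1ccc2c(c1)C(=O)N(CCC1CCNCC1)C2)C(=O)O`: 16 nM
Compound 3 `O=C(NC[C@H](NS(=O)(=O)c1cccs1)C(=O)O)c1ccc2c(c1)C(=O)N(CCC1CCNCC1)C2`: 7 nM
Compound 4 `O=C(NC[C@H](NS(=O)(=O)Cc1ccccc1)C(=O)O)c1ccc2c(c1)C(=O)N(CCC1CCNCC1)C2`: not yet measured

In a functional assay for inhibition, with Homo sapiens as the target (on this read-out lower numbers stand for stronger inhibition and higher numbers for weaker inhibition), compound 3 gives 7 nM, the lower of the two compounds with a single number. Compound 1 has no single number, and its record reads (the several entries of compound 1 in this assay, 14 nM; 9 nM (2 entries)). Among the measured compounds shown here, the one measured step reaching compound 3 is a 2.3-fold lower number from compound 2 to compound 3 (0.36 log units; beyond the scatter), a modest move.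

Compound 4 changes compound 3 in one place: benzyl in place of thiophen-2-yl on a sulfonyl sulfur. For the measured compounds named here, no measured step makes this exact swap, so the evidence is indirect. The step from compound 2 concerns a different swap on the same amine nitrogen, and it stayed modest. Compound 1, with a butyl chain on the sulfonyl group instead of a ring, gives 14 nM; 9 nM (2 entries) in this assay. A large change therefore seems unlikely, and no shift beyond the scatter is expected. The expected step is a 1.4-fold higher number from compound 3 to compound 4 (0.15 log units; within the scatter). The estimate for compound 4 is 10 nM, with an expected range from 4 nM to 25 nM.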

Compound 4, half-maximal inhibitory concentration: 4 nM
Compound 4: the middle estimate sits 2.5-fold (0.40 log units) above what was measured, within the range that was stated.
By their numbers in this assay, from the lowest: compounds 4 and 3 (each within the scatter of the next); then compound 2.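

In this assay, benzyl on the sulfonyl sulfur gives a 1.8-fold lower number from compound 3 to compound 4 (0.24 log units; within the scatter), so at this position a six-membered aromatic ring of carbon only reads the same as a five-membered aromatic ring with 1 hetero atom. On the amine nitrogen, benzylsulfonyl in place of butylcarbamoyl gives a 4.0-fold lower number from compound 2 to compound 4 (0.60 log units; beyond the scatter), which makes it the second sulfonyl group, after (thiophen-2-yl)sulfonyl, to stand beyond the scatter from compound 2. A butyl chain on the same sulfur, in compound 1, has no single number to set beside these: the several entries of compound 1 in this assay, 14 nM; 9 nM (2 entries)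

The compounds shown leave open how a phenethyl group, or a benzyl ring carrying a chlorine or a methoxy group, would read on this sulfonyl sulfur. They also leave open what an ester in place of the carboxylic acid would do with the benzylsulfonyl group in place.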